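The source may hold more compounds than are shown below. What is called first, only, known or untested is meant among the compounds shown, and "the series" means these compounds.

Three compounds sharing one core were tested in an ADME assay on TZM-b1 cells (Homo sapiens) for cytotoxicity, read by XTT assay, with a stated time of 3 days; on this read-out lower numbers stand for higher toxicity in this test and higher numbers for lower toxicity in this test. Compound 1 `Cc1nc(C(NC(=O)C(=O)Nc2ccc(F)cc2F)C2CCCCN2)sc1CO` carries a 2,4-difluorophenyl group on an amide-type nitrogen. In this assay compound 1 gives > 87000 nM, which is a limit of the test and not a number. Compound 2 `Cc1nc(C(NC(=O)C(=O)Nc2ccc(Cl)cc2)C2CCCCN2)sc1CO` has a 4-chlorophenyl group in that place. In this assay compound 2 gives > 22000 nM, again a limit rather than a number. Compound 3 `Cc1nc(C(NC(=O)C(=O)Nc2ccc(F)c(Cl)c2)C2CCCCN2)sc1CO` carries a 3-chloro-4-fluorophenyl group there. In this assay compound 3 gives > 77800 nM, once more a limit. Compound 2 thus stands, like the other two, only at a limit, with no number behind it: the limit of > 22000 nM in this assay, at which 1 of the 3 values shown sits, the limit of > 77800 nM in this assay, at which 1 of the 3 values shown sits, and the limit of > 87000 nM in this assay, at which 1 of the 3 values shown sits, are all that is known. The steps between the measured compounds, a step that the two limits leave unreadable from compound 1 to compound 2, a step that the two limits leave unreadable from compound 1 to compound 3 and a step that the two limits leave unreadable from compound 2 to compound 3, cannot be read in size, as both ends of each are limits.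

The unmeasured compound 4 `Cc1nc(C(NC(=O)C(=O)Nc2ccc(Cl)cc2)C2CCCNC2)sc1CO` differs from compound 2 in one place: piperidin-3-yl in place of piperidin-2-yl on a saturated chain carbon bound to an amide-type nitrogen and an aromatic carbon. Among the compounds with values here, none of the measured steps changes this part of the molecule, so none bears directly on it, and no step beyond the scatter can be expected from them. Compound 4 in this assay is therefore expected to give a value near the known limits, 50000 nM, with a range from 15000 nM to 200000 nM. The expected step that the limit leaves unreadable from compound 2 to compound 4 is accordingly estimated to stay within the scatter.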

Compound 4, half-maximal cytotoxic concentration: 60200 nM
The estimate for compound 4 lay 1.2-fold (0.08 log units) below the measured number; the range from low to high includes it.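

Compound 2 is known in this assay only as a limit, so no size can be read for the step to compound 4, even though compound 4 has a real number. Left open is whether piperidin-3-yl in place of piperidin-2-yl shifts this read-out at all, and how the groups on the amide-type nitrogen of compound 1, compound 2 and compound 3 compare.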